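Three inactive macrocycles and a larger side chain

A few compounds are considered here, and "the series" means these few. Any claim that something is new, unique, unknown or untested is made for them only; others in the source may bear on it.

- Compound 1 `N#Cc1ncc2nc1OCC/C=C\COc1ccc(Br)cc1NC(=O)N2` gives > 10000 nM as a limit
- Compound 2 `N#Cc1ncc2nc1OCC/C=C\COc1ccccc1NC(=O)N2` gives > 10000 nM as a limit
- Compound 3 `N#Cc1ncc2nc1OCC/C=C\COc1ccc(Cl)cc1NC(=O)N2` gives > 10000 nM as a limit

All three were read in a functional assay on NCI-H1299 cells (Homo sapiens), read by flow cytometry (a higher number here means that more compound is needed for the effect, a lower number that less compound is needed), and none has a true number. Compound 3 stands at > 10000 nM, which is a limit and not a number. The whole picture so far is the limit of > 10000 nM in this assay, at which 3 of the 3 values shown sit, and nothing more.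

Compound 4 `N#Cc1ncc2nc1OCC/C=C\COc1ccc(CCOC3CCCCO3)cc1NC(=O)N2` keeps the shared core and changes one group: 2-((oxan-2-yl)oxy)ethyl in place of chloro on an aromatic carbon. The measured swaps at this place are a step that the two limits leave unreadable from compound 2 to compound 3, a step that the two limits leave unreadable from compound 1 to compound 3 and a step that the two limits leave unreadable from compound 1 to compound 2, so no size can be carried over. With nothing readable to lean on, the expected change is a number no higher from compound 3 to compound 4 (the limit leaves the size open) as a rough guess with no firm direction. Compound 4 is estimated at 10000 nM, with an expected range from 3000 nM to 30000 nM and a good chance of another limit.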

Compound 4, half-maximal effective concentration: > 10000 nM
Compound 4: a limit, no number; the forecaster's own chance of this, stated with the estimate: 75%; the middle value sits exactly at the limit.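

In this assay compound 4 gives > 10000 nM, which is a limit and not a number, so its steps from compound 1, compound 2 and compound 3 cannot be read. Still open is how these four compounds truly rank, and whether any group at this place would give a true number: the limit of > 10000 nM in this assay, at which 4 of the 4 values shown sit.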